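Bile acid receptor agonists: carboxyphenyl attachment variants

A few compounds are considered here, and "the series" means these few. Any claim that something is new, unique, unknown or untested is made for them only; others in the source may bear on it.

Measured compounds:
compound 1, `CC(c1ccc(OCc2c(-c3c(Cl)cccc3Cl)noc2C2CC2)nc1C(F)(F)F)N(C)c1ccc(C(=O)O)cc1`, 57%
compound 2, `O=C(O)c1ccccc1OCc1ccc(OCc2c(-c3c(Cl)cccc3Cl)noc2C2CC2)nc1C(F)(F)F`, 33%

In a functional assay on HEK293 cells for agonist activity at Bile acid receptor (Homo sapiens), read by a luciferase reporter (a lower number here means a smaller maximal response, a higher number a larger maximal response), compound 1 `CC(c1ccc(OCc2c(-c3c(Cl)cccc3Cl)noc2C2CC2)nc1C(F)(F)F)N(C)c1ccc(C(=O)O)cc1` reaches 57%. Among the compounds with values here, compound 2 `O=C(O)c1ccccc1OCc1ccc(OCc2c(-c3c(Cl)cccc3Cl)noc2C2CC2)nc1C(F)(F)F` reaches 33% in this assay and stands lowest of the two numbers; its only neighbour, compound 1, lies higher by a gap beyond the scatter. Within the data shown here, no two measured compounds differ in a single place, so no measured single step exists.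

Compound 3 `CC(Oc1ccc(C(=O)O)cc1)c1ccc(OCc2c(-c3c(Cl)cccc3Cl)noc2C2CC2)nc1C(F)(F)F` is not yet measured. It differs from compound 2 as follows: 1-(4-carboxyphenoxy)ethyl in place of (2-carboxyphenoxy)methyl on an aromatic carbon. The 1-(4-carboxyphenoxy)ethyl group brings the carboxylic acid into the same position on the phenyl ring as in compound 1 and adds the ethyl branch that compound 1 also carries, while the phenoxy attachment of compound 2 is kept.

An upward step is expected from compound 2 to compound 3 in this assay, of moderate size and beyond the scatter, a number 17 percentage points higher from compound 2 to compound 3 (beyond the scatter), since compound 1 gives 57%. Compound 3 is therefore estimated at 50% in this assay, within a range from 28% to 75%.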

Compound 3, largest response reached (reported as efficacy), in percent of the reference or control that the assay uses: 33%
Compound 3: middle estimate off by 17 percentage points, on the high side, and the stated range covers the measured number.
By their numbers in this assay, from the lowest: compounds 2 and 3 (each within the scatter of the next); then compound 1.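

Within this assay, the exchange on this aromatic carbon, ortho to a trifluoromethyl group, gives no change at the digits printed from compound 2 to compound 3 (within the scatter), so 1-(4-carboxyphenoxy)ethyl and (2-carboxyphenoxy)methyl cannot be told apart at this position in this read-out. Within the data shown here, the second step, a number 24 percentage points lower from compound 1 to compound 3 (beyond the scatter), is the first comparison that isolates the atom linking the chain carbon to the carboxyphenyl ring: 4-carboxyphenoxy in place of (4-carboxyphenyl)(methyl)amino, with the ethyl branch and the 4-carboxy placement held constant, so the branch and that placement do not by themselves keep the higher response of compound 1. No measurement on hand accounts for either step.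

The exchange from compound 2 to compound 3 alters the acid placement and the branch together, so the compounds shown cannot separate these two changes or say whether each is silent or their contributions offset. Also open, as far as these compounds go, is how the maximal response would respond to a (4-carboxyphenyl)amino group without the methyl, or to a thioether link in place of the ether oxygen of compound 3.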